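Dimethylamino on the terminal phenyl of compound 1

This account rests on a few compounds, and the source may have more. Where it says the series, first, only, none or still open, it means among the compounds named here.

- compound 1 `c1ccc(-c2ccc(-c3ccc(-c4nc5ccccc5[nH]4)cc3)cc2)cc1` gives 32100 nM
- compound 2 `FC(F)(F)c1ccc(-c2ccc(-c3ccc(-c4nc5ccccc5[nH]4)cc3)cc2)cc1` gives 100000 nM
- compound 3 `Oc1ccc(-c2ccc(-c3ccc(-c4nc5ccccc5[nH]4)cc3)cc2)cc1` gives 36000 nM
- compound 4 `CN(C)c1ccc(-c2ccc(-c3ccc(-c4nc5ccccc5[nH]4)cc3)cc2)cc1` is not yet measured

In a functional assay on A2780 cells (Homo sapiens) for inhibition, read by sulforhodamine B assay (a lower number here means a stronger inhibitor of growth, a higher number a weaker inhibitor of growth), compound 1 shares the low end of the three numbers with compound 3 (a 1.1-fold higher number from compound 1 to compound 3 (0.05 log units; within the scatter)). Compound 2 stands apart from both (a 3.1-fold higher number from compound 1 to compound 2 (0.49 log units; beyond the scatter); a 2.8-fold lower number from compound 2 to compound 3 (0.44 log units; beyond the scatter)).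

The step to compound 4 is phenyl to 4-(dimethylamino)phenyl, with dimethylamino in place of hydrogen on an aromatic carbon, para to a large group (dimethylamino in place of hydrogen on an aromatic carbon). For the measured compounds named here, two measured steps bear on it, since each also replaces hydrogen on that carbon. Hydroxy left no separation from compound 1 in compound 3 (value 36000 nM), while trifluoromethyl in compound 2 gave a modest rise in the number (value 100000 nM). Neither step lowered the number beyond the scatter. Going by the values given here, no measured compound carries dimethylamino, so the direction rests on these two cases alone.

No step beyond the scatter is expected, although a modest rise cannot be excluded. The expected step is small (a 1.1-fold higher number from compound 1 to compound 4 (0.04 log units; within the scatter)). For compound 4 the estimated value is 35000 nM (expected range 12000 nM to 100000 nM).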

Compound 4, concentration for 50% growth inhibition: 100000 nM
Compound 4: middle estimate off by 2.9-fold (0.46 log units), on the low side, and the stated range covers the measured number.
By their numbers in this assay, from the lowest: compounds 1 and 3 (each within the scatter of the next); then compounds 2 and 4 (each within the scatter of the next).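

In this assay, dimethylamino on this aromatic carbon gives a modest rise (a 3.1-fold higher number from compound 1 to compound 4 (0.49 log units; beyond the scatter)), making it the second group after trifluoromethyl to separate from hydrogen here, and it also separates from hydroxy (a 2.8-fold higher number from compound 3 to compound 4 (0.44 log units; beyond the scatter)). Dimethylamino and trifluoromethyl cannot be told apart in this assay (no change at the digits printed from compound 2 to compound 4 (within the scatter)), so the two replacements share the high end of the numbers, while compound 3 goes against any general rise on substitution at this carbon. None of the three replacements of hydrogen lowers the number beyond the scatter, and no measurement at hand accounts for why hydroxy stands apart from the other two groups.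

As far as these compounds go, it remains open whether a primary amine, a methoxy group or a carboxylic acid on this carbon would stay with hydroxy or join dimethylamino and trifluoromethyl. Also open, from the compounds shown here alone, is whether any group here can bring the number below that of compound 1 by more than the scatter.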